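Trifluoromethyl for methoxy: expected growth inhibition of compound 4

This account rests on a few compounds, and the source may have more. Where it says the series, first, only, none or still open, it means among the compounds named here.

Measured so far:
compound 1 `O=C(Nc1cccc(C(F)(F)F)c1)C1NCCc2ccccc21` — > 10000 nM
compound 2 `O=C(Nc1ccc(C(F)(F)F)cc1)c1nccc2ccccc12` — > 10000 nM
compound 3 `COc1cccc(NC(=O)c2nccc3ccccc23)c1` — > 10000 nM

In a functional assay on NUGC-3 cells (Homo sapiens) for inhibition, read by sulforhodamine B assay, with a stated time of 48 h (a higher number here means a weaker inhibitor of growth, a lower number a stronger inhibitor of growth), compound 1 gives > 10000 nM, which is a limit of the assay and not a number. Compound 2 gives > 10000 nM, also a limit. Compound 3 gives > 10000 nM, again a limit. Compound 3 thus stands with the other two at the limit of > 10000 nM in this assay, at which 3 of the 3 values shown sit; none of the three separates from the others, and no comparison of potency among them can be drawn.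

Compound 4 `O=C(Nc1cccc(C(F)(F)F)c1)c1nccc2ccccc12` is not yet measured. It differs from compound 3 by trifluoromethyl in place of methoxy on an aromatic carbon, so compound 4 carries the same amine part as compound 1 on the core of compound 3. Among the measured compounds shown here, no step between measured compounds that differ in one place is available, so no measured size of a step can be quoted.

The expectation for this assay is that the change from compound 3 to compound 4 gives no step beyond the scatter, with the result most likely remaining a limit; the estimated step is a step that the limit leaves unreadable from compound 3 to compound 4. Compound 4 is expected to give about 15000 nM, within a range from 5000 nM to 50000 nM.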

Compound 4, concentration for 50% growth inhibition: > 10000 nM
Compound 4 ended at the assay's limit; the forecaster's own chance of this, stated with the estimate: 75%; the middle value does not contradict the limit.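

In this assay compound 4 gives > 10000 nM, a limit of the assay and not a number. Compound 3 also sits at a limit, so no step can be read between compound 3 and compound 4: the limit of > 10000 nM in this assay, at which 4 of the 4 values shown sit.

The compounds shown leave open whether any change to this series brings growth inhibition into the readable range.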